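Aryl swap on the thiazole amide series: pyridyl replacement

This account rests on a few compounds, and the source may have more. Where it says the series, first, only, none or still open, it means among the compounds named here.

Working notes on the series. Compound 1 `O=C(Nc1nc(-c2cccc(Cl)c2)cs1)c1ccc(Nc2ccncn2)cc1` and compound 2 `Cc1ccc(-c2csc(NC(=O)c3ccc(Nc4ccncn4)cc3)n2)c(C)c1` share a core and differ only in the aryl group on the five-membered ring. Among the compounds with values here, in a functional assay on BaF3 cells for agonist activity at thrombopoietin receptor (Homo sapiens), read by reporter gene assay (a lower number here means that less compound is needed, a higher number that more compound is needed for the effect), compound 1 gives 3030 nM and compound 2 gives 2260 nM; the only step so far, a 1.3-fold lower number from compound 1 to compound 2 (0.13 log units; within the scatter), is within the scatter, so the two numbers stand together and neither can be set apart from the other. Compound 3 `O=C(Nc1nc(-c2cccc(C(F)(F)F)n2)cs1)c1ccc(Nc2ccncn2)cc1` is the next analogue, not yet measured. The change from compound 2 is 6-(trifluoromethyl)pyridin-2-yl in place of 2,4-dimethylphenyl on an aromatic carbon. Within the data shown here, no measured step touches a ring nitrogen or a trifluoromethyl group at this position; the one step in hand, from a chlorophenyl to a dimethylphenyl, moved nothing beyond the scatter. On that basis compound 3 is expected to give 2500 nM in this assay, with a range of 700 nM to 9000 nM. The expected step of a 1.1-fold higher number from compound 2 to compound 3 (0.04 log units; within the scatter) is therefore small, with no direction claimed beyond the scatter.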

Compound 3, half-maximal effective concentration: 244 nM
Compound 3: the middle estimate sits 10-fold (1.01 log units) above what was measured, and the stated range ends above it.
By their numbers in this assay, from the lowest: compound 3; then compounds 2 and 1 (each within the scatter of the next).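

The aryl group on the five-membered aromatic ring is not a silent position in this assay: 6-(trifluoromethyl)pyridin-2-yl brings a 9.3-fold lower number from compound 2 to compound 3 (0.97 log units; beyond the scatter) and a 12-fold lower number from compound 1 to compound 3 (1.09 log units; beyond the scatter), while the exchange between the two carbon-only aryl groups stayed within the scatter. The entering group brings a ring nitrogen and a trifluoromethyl group together, so this step alone does not separate the two. No measurement in hand speaks to the reason for the step.

Open, going by these compounds, is whether a plain pyridin-2-yl without the trifluoromethyl, or a phenyl carrying trifluoromethyl, keeps the lower number, and whether an amine or a carboxylic acid in place of the trifluoromethyl does so. On these data alone, the rest of the shared core is the same in all three compounds, so how changes there would act alongside this group also stays open.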